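Notes on a three-compound series and one planned analogue

This account rests on a few compounds, and the source may have more. Where it says the series, first, only, none or still open, it means among the compounds named here.

compound 1 `COc1ccc(SCc2ccc(/C=C/C(=O)Nc3ccccc3N)cc2)cc1OC` — 10.1%
compound 2 `COc1ccc(SCc2ccc(C(=O)Nc3ccccc3N)cc2)cc1` — 35%
compound 3 `Nc1ccccc1NC(=O)c1ccc(CSc2nccc(C(F)(F)F)n2)cc1` — 68.3%

In a functional assay on HeLa cells (Homo sapiens) for inhibition, read by CCK-8 assay, with a stated time of 72 h, tested at 2 uM (on this read-out lower numbers stand for less inhibition of growth and higher numbers for more inhibition of growth at the one concentration tested), compound 1 gives 10.1%, the lowest of the three numbers. Compound 2 lies higher, beyond the scatter, and compound 3 higher still, beyond the scatter. For the measured compounds named here, no pair among the three differs in only one place, so no single-change step can be read from them; compounds 2 and 3 each differ from compound 1 in several places at once.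

Compound 4 `Nc1ccccc1NC(=O)/C=C/c1ccc(CSCCc2ccccc2)cc1` differs from compound 1 by phenethyl in place of 3,4-dimethoxyphenyl on a sulfur. Nothing measured isolates this change. A modest upward step is expected, a number 11.9 percentage points higher from compound 1 to compound 4 (beyond the scatter), of a size close to the edge of the scatter. Compound 4 is expected to give 22%, within 5% to 45%.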

Compound 4, percent growth inhibition at one concentration: 0.19%
For compound 4 the middle estimate is 21.8 percentage points above the measured one; measured number outside the range, below it.
By their numbers in this assay, from the lowest: compounds 4 and 1 (each within the scatter of the next); then compound 2; then compound 3.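

Phenethyl in place of 3,4-dimethoxyphenyl on a sulfur gives the first single-place comparison in the series: in this assay it is a number 9.9 percentage points lower from compound 1 to compound 4 (within the scatter). On the core of compound 1, this exchange therefore produces no change that can be told from the scatter, although the entering group carries no hydrogen-bond acceptors and the leaving group does. No evidence at hand bears on this result.

As far as these compounds go, whether a longer chain or an amine on this sulfur would move the number away from compound 1 stays open. The gaps separating compound 2 and compound 3 from compound 1 also remain unassigned to any single place.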